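Swapping methyl for 4-methoxyphenyl on a weak compound

The source may report more compounds than this note shows. Statements on the series, on what has been measured and on what is new or still open speak of the compounds shown alone.

Compound 1 `COc1ccc(-n2cc(NC(=O)c3cccc(NS(=O)(=O)c4ccccc4)c3)cn2)cc1`: 76800 nM
Compound 2 `Cn1cc(NC(=O)c2ccc(NS(=O)(=O)c3ccccc3)cc2)cn1`: > 100000 nM

Both compounds were tested in a functional assay on A549 cells (Homo sapiens) for inhibition, read by MTT assay, with a stated time of 48 h; a higher number here means a weaker inhibitor, a lower number a stronger inhibitor. Compound 2 gives no actual number in this assay, because its entry of > 100000 nM is only a limit of the assay. Compound 3 `COc1ccc(-n2cc(NC(=O)c3ccc(NS(=O)(=O)c4ccccc4)cc3)cn2)cc1` differs from compound 2 by carrying 4-methoxyphenyl in place of methyl on an aromatic nitrogen. Going by the values given here, no measured pair of compounds isolates this swap, so any expectation here is loose. Compound 1 also carries 4-methoxyphenyl and reads 76800 nM in this assay, so a modest move towards a lower number is expected. The result for compound 3 may again stop at the limit of the assay. The expected size of the change is an at least 1.6-fold lower number from compound 2 to compound 3 (0.22 log units; that floor lies within the scatter). For compound 3 the estimate is 60000 nM, with an expected range of 25000 nM to 100000 nM.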

Compound 3, half-maximal inhibitory concentration: 85800 nM
For compound 3 the middle estimate is 1.4-fold (0.16 log units) below the measured one, and the stated range covers the measured number.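

Swapping methyl for 4-methoxyphenyl on the aromatic nitrogen gives, in this assay, an at least 1.1-fold lower number from compound 2 to compound 3 (0.06 log units; that floor lies within the scatter). This is the only step shown that changes this position alone, and with the larger group compound 3 gives a real number, 85800 nM, although it remains a weak inhibitor. The true size of the step stays unknown because compound 2 carries a limit and not a number: the limit of > 100000 nM in this assay, at which 1 of the 3 values shown sits.

The compounds shown leave open what other groups on this nitrogen would do, such as an ethyl chain, an unsubstituted phenyl, or a phenyl ring bearing a carboxylic acid or an amine. They also leave open whether any group at this position can bring the number far below that of compound 3.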